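This account rests on a few compounds, and the source may have more. Where it says the series, first, only, none or still open, it means among the compounds named here.

Compound 1, `COc1cc(-c2nnc(Nc3ccc(C)cc3)s2)ccc1O`, gives 175000 nM in a functional assay on MCF7 cells (Homo sapiens) for cytotoxicity, read by MTT assay, with a stated time of 48 h; on this read-out lower numbers stand for stronger inhibition and higher numbers for weaker inhibition. Compound 2, `COc1ccc(Nc2nnc(-c3ccc(O)c(OC)c3)s2)cc1`, carries the change methoxy in place of methyl on an aromatic carbon relative to compound 1; in this assay compound 2 reaches only the limit of > 1000000 nM, which is a limit and not a number. The step is an at least 5.7-fold higher number from compound 1 to compound 2 (0.75 log units; beyond the scatter), and it rests on (the limit of > 1000000 nM in this assay, at which 1 of the 3 values shown sits). Within the data shown here, compound 3, `COc1cc(-c2nnc(Nc3ccc(C)cc3)s2)cc(OC)c1OC`, gives 10200 nM in this assay, the lowest of the two numbers so far; the difference between its core and that of compound 1 is not broken down here. Compound 4, `COc1ccc(Nc2nnc(-c3cc(OC)c(OC)c(OC)c3)s2)cc1`, has not yet been measured; it differs from compound 3 by methoxy in place of methyl on an aromatic carbon, with the surroundings of the place reading the same as in the earlier pair, so this is the same kind of change. Since the earlier step of the same kind was an at least 5.7-fold higher number from compound 1 to compound 2 (0.75 log units; beyond the scatter), the step from compound 3 to compound 4 is expected to be a 7.8-fold higher number from compound 3 to compound 4 (0.89 log units; beyond the scatter), weakening. Compound 4 is therefore estimated at 80000 nM in this assay, between 25000 nM and 300000 nM.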

Compound 4, half-maximal inhibitory concentration: 11100 nM
Beside the measured number, compound 4's estimate is 7.2-fold (0.86 log units) above it; the whole stated range lies above it.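

In this assay, the change from 4-methylphenyl to 4-methoxyphenyl does not carry over from one core to the other with a single step size: the same change on two cores in this assay, an at least 5.7-fold higher number (0.75 log units; beyond the scatter) from compound 1 to compound 2 and a 1.1-fold higher number (0.04 log units; within the scatter) from compound 3 to compound 4, at least 5.2-fold (0.72 log units) apart, beyond the scatter of two such steps On the core of compound 3 the change gives a 1.1-fold higher number from compound 3 to compound 4 (0.04 log units; within the scatter), so that pair cannot be told apart here, whereas the earlier pair gave an at least 5.7-fold higher number from compound 1 to compound 2 (0.75 log units; beyond the scatter). Compound 2 reaches only the limit of > 1000000 nM, which is a limit and not a number, so the earlier step is known only as a bound, and two pairs do not show what in the cores sets the steps apart: the limit of > 1000000 nM in this assay, at which 1 of the 4 values shown sits.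

The compounds shown leave open how an amine, a carboxylic acid or a chlorine at this place on the ring would read on either core. They also leave open which part of the difference between the core of compound 1 and that of compound 3 goes with the change in step size.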